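Swapping Thiophene for Pyrrole on a Weakly Active Core

The compounds below may be only part of what the source reports. "The series", "measured", "known", "first", "only" and "open" are said of these compounds alone.

Of the compounds shown here, three that share one core have been tested in a functional assay on HCT-116 cells (Homo sapiens) for inhibition, read by MTT assay; on this read-out higher numbers stand for weaker inhibition and lower numbers for stronger inhibition. Compound 1 `Nc1nc(-c2ccccc2)cc(-c2cnn(-c3ccccc3)n2)n1` gives 120000 nM in this assay. Compound 2 `Nc1nc(-c2ccc([N+](=O)[O-])cc2)cc(-c2cnn(-c3ccccc3)n2)n1` carries a nitro group where compound 1 carries hydrogen, and compound 2 gives 133000 nM; the step of a 1.1-fold higher number from compound 1 to compound 2 (0.04 log units; within the scatter) is within the scatter, so the two cannot be separated. Compound 3 `Nc1nc(-c2ccccc2)cc(-c2cccs2)n1` gives 57000 nM in this assay, the lowest of the three numbers, with compound 1 and compound 2 both beyond the scatter above it.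

Compound 4 `Nc1nc(-c2ccccc2)cc(-c2ccc[nH]2)n1` differs from compound 3 by 1H-pyrrol-2-yl in place of thiophen-2-yl on an aromatic carbon. No measured step resembles this change: the single step shown, from compound 1 to compound 2, concerns a nitro group at another place on the core and stays within the scatter, so it gives no guidance on either size or direction here. With nothing to lean on, the reasonable expectation is no step beyond the scatter from compound 3, and the expected step of a 1.1-fold lower number from compound 3 to compound 4 (0.06 log units; within the scatter) reflects that. Compound 4 is therefore estimated to give about 50000 nM in this assay, within a range from 15000 nM to 150000 nM.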

Compound 4, half-maximal inhibitory concentration: 55500 nM
For compound 4 the middle estimate is 1.1-fold (0.05 log units) below the measured one; the measured number falls inside the stated range.
By their numbers in this assay, from the lowest: compounds 4 and 3 (each within the scatter of the next); then compounds 1 and 2 (each within the scatter of the next).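

In this assay, putting 1H-pyrrol-2-yl in place of thiophen-2-yl gives a 1.0-fold lower number from compound 3 to compound 4 (0.01 log units; within the scatter), so the two compounds cannot be told apart. Among these compounds, this pair gives the first direct reading at this position, on the aromatic carbon next to the ring nitrogen, and it shows that this read-out does not separate the two five-membered aromatic rings, even though one carries sulfur and the other nitrogen, and the swap replaces a hydrogen-bond acceptor with a hydrogen-bond donor. No measurement shown here explains why the two compounds fall within the scatter of each other, and this single pair supports no wider rule.

Still open, going by these compounds, is whether a group of a different kind at this position, such as an amine, a carboxylic acid or a longer chain, would move the number beyond the scatter from compound 3 and, if so, in which direction. Also open, on these data alone, is whether the same exchange would again stay within the scatter with a nitro group on the phenyl ring, the change already seen between compounds carrying a different group at this position.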